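Dropping a Fluoro Group: Compound 3 to Compound 4

The source may report more compounds than this note shows. Statements on the series, on what has been measured and on what is new or still open speak of the compounds shown alone.

Measured in a functional assay on A549 cells (Homo sapiens) for antiproliferative activity, read by MTT assay, with a stated time of 72 h; on this read-out lower numbers stand for stronger inhibition and higher numbers for weaker inhibition:
Compound 1 `C#Cc1cccc(Nc2ncnc3ccc(NC(=S)Nc4ccc(S(N)(=O)=O)cc4)cc23)c1`: a limit, > 40000 nM.
Compound 2 `NS(=O)(=O)c1ccc(NC(=S)Nc2ccc3ncnc(Nc4ccc(Cl)c(C(F)(F)F)c4)c3c2)cc1`: 4500 nM.
Compound 3 `NS(=O)(=O)c1ccc(NC(=S)Nc2ccc3ncnc(Nc4ccc(F)c(Br)c4)c3c2)cc1`: a limit, > 40000 nM.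

Compound 3 sits at the limit of > 40000 nM in this assay, at which 2 of the 3 values shown sit, so no number is known for it. Compound 4 `NS(=O)(=O)c1ccc(NC(=S)Nc2ccc3ncnc(Nc4cccc(Br)c4)c3c2)cc1` differs from compound 3 by hydrogen in place of fluoro on an aromatic carbon. Every measured step swaps the whole aryl group on the shared core: an at least 8.8-fold lower number from compound 1 to compound 2 (0.94 log units; beyond the scatter) and an at least 8.8-fold higher number from compound 2 to compound 3 (0.94 log units; beyond the scatter) moved the number strongly, while a step that the two limits leave unreadable from compound 1 to compound 3. Within the data shown here, none of them removes a single fluoro, so no step bears directly on this small change. For compound 4 the expected step is a number no higher from compound 3 to compound 4 (the limit leaves the size open), nothing beyond the scatter. The estimate for compound 4 is 40000 nM, within 12000 nM to 120000 nM, most likely again reported only as a limit.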

Compound 4, half-maximal inhibitory concentration: 25000 nM
Compound 4: middle estimate off by 1.6-fold (0.20 log units), on the high side; measured number inside the range.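

In this assay, hydrogen in place of fluoro gives an at least 1.6-fold lower number from compound 3 to compound 4 (0.20 log units; that floor lies within the scatter), so this change has only a floor and its true size stays hidden: the limit of > 40000 nM in this assay, at which 2 of the 4 values shown sit. Bromo in place of ethynyl likewise gives only a floor, with an at least 1.6-fold lower number from compound 1 to compound 4 (0.20 log units; that floor lies within the scatter). Against a real number, 3-bromophenyl still falls short of 4-chloro-3-(trifluoromethyl)phenyl, with a 5.6-fold higher number from compound 2 to compound 4 (0.74 log units; beyond the scatter).

Going by these compounds, whether a methoxy group or an amine on that aromatic carbon would lower the number stays open. So does how much the fluoro itself matters.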